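One Oxadiazole Exchanged for Another

The compounds below may be only part of what the source reports. "The series", "measured", "known", "first", "only" and "open" are said of these compounds alone.

Three related compounds have been tested in a functional assay on MIA PaCa-2 cells (Homo sapiens) for inhibition, read by MTT assay, with a stated time of 7 days; on this read-out higher numbers stand for weaker inhibition and lower numbers for stronger inhibition. Compound 1 `CCN(CC)C(=O)c1ccc(S(=O)(=O)N2CCC[C@@H](C(=O)N3CCN(c4nc(C(C)C)no4)CC3)C2)cc1` gives 100 nM, compound 2 `CC(C)c1noc(N2CCN(C(=O)[C@@H]3CCCN(S(=O)(=O)c4ccc(S(=O)(=O)NC(C)(C)C)cc4)C3)CC2)n1` gives 300 nM, and compound 3 `CCN(CC)S(=O)(=O)c1ccc(S(=O)(=O)N2CCC[C@@H](C(=O)N3CCN(c4nnc(C(C)C)o4)CC3)C2)cc1` gives 1800 nM, the highest number of the three and so the weakest inhibition in this small set.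

Compound 4 `CCN(CC)S(=O)(=O)c1ccc(S(=O)(=O)N2CCC[C@@H](C(=O)N3CCN(c4nc(C(C)C)no4)CC3)C2)cc1` has the same atoms as compound 3, joined differently, with 3-isopropyl-1,2,4-oxadiazol-5-yl in place of 5-isopropyl-1,3,4-oxadiazol-2-yl on an amine nitrogen in a ring.

Among the compounds with values here, no measured step makes this exchange directly. Within the data shown here, the only step available, a 3.0-fold higher number from compound 1 to compound 2 (0.48 log units; beyond the scatter), replaces diethylcarbamoyl with (tert-butyl)sulfamoyl on an aromatic carbon, so it concerns a different place in the molecule. The better hint comes from compound 1 at 100 nM and compound 2 at 300 nM, since both carry the entering group, although each also differs from compound 3 at that aromatic carbon. The comparison is therefore imperfect, but it points one way. The expected change is a 7.2-fold lower number from compound 3 to compound 4 (0.86 log units; beyond the scatter), a lower number and so stronger inhibition in this assay. For compound 4 the estimated value is 250 nM, with a likely range from 80 nM to 800 nM.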

Compound 4, half-maximal inhibitory concentration: 50 nM
The estimate for compound 4 lay 5.0-fold (0.70 log units) above the measured number; the whole stated range lies above it.
By their numbers in this assay, from the lowest: compounds 4 and 1 (each within the scatter of the next); then compound 2; then compound 3.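

Within the data shown here, exchanging one oxadiazole for the other on the amine nitrogen, with everything else in the molecule unchanged, gives a 36-fold lower number from compound 3 to compound 4 (1.56 log units; beyond the scatter) in this assay and shows that how the same atoms are joined in this group matters greatly at this position, which no earlier step could show. With 3-isopropyl-1,2,4-oxadiazol-5-yl kept in place, diethylamino in place of (tert-butyl)amino on the sulfonyl sulfur gives a 6.0-fold lower number from compound 2 to compound 4 (0.78 log units; beyond the scatter) while diethylsulfamoyl in place of diethylcarbamoyl gives a 2.0-fold lower number from compound 1 to compound 4 (0.30 log units; within the scatter) so only the first of these two changes can be told apart from the scatter. Nothing available explains why the exchange of oxadiazoles has so large an effect.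

On these data alone, only compound 3 carries 5-isopropyl-1,3,4-oxadiazol-2-yl, so it remains open whether the exchange would have a similar size with diethylcarbamoyl or (tert-butyl)sulfamoyl on the aromatic carbon. All the compounds shown carry isopropyl on the oxadiazole, so what a cyclopropyl or a trifluoromethyl group would do in its stead also remains open.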